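Sulfonyl substituent change in a prostaglandin D2 receptor 2 series

A few compounds are considered here, and "the series" means these few. Any claim that something is new, unique, unknown or untested is made for them only; others in the source may bear on it.

Three compounds have numbers in an assay on CHO cells for displacement of a labelled ligand from prostaglandin D2 receptor 2 (Homo sapiens), read by scintillation counting; on this read-out higher numbers stand for weaker inhibition and lower numbers for stronger inhibition. Compound 1 `CN(c1cccc(C#Cc2cc(Cl)ccc2OCC(=O)O)c1)S(C)(=O)=O` gives 122 nM in this assay, compound 3 `CCCS(=O)(=O)c1cccc(C#Cc2c(Cl)cccc2OCC(=O)O)c1` gives 55 nM, and compound 2 `COCCN(C)S(=O)(=O)c1ccc(C)c(C#Cc2cc(Cl)ccc2OCC(=O)O)c1` gives 4.1 nM. Compound 2 therefore holds the lowest number of the three; its gap to compound 3 and its larger gap to compound 1 both lie beyond the usual scatter, so compound 2 is the strongest inhibitor seen so far in this assay.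

Compound 4 `CCS(=O)(=O)c1ccc(C)c(C#Cc2cc(Cl)ccc2OCC(=O)O)c1` has not yet been measured. It differs from compound 2 in one place: ethyl in place of (2-methoxyethyl)(methyl)amino on a sulfonyl sulfur. The whole (2-methoxyethyl)(methyl)sulfamoyl group becomes ethylsulfonyl; the rest of the shared core is unchanged.

Among the compounds with values here, no pair of measured compounds shows this exact change, so the size of the step is open. Compound 3, which carries a propylsulfonyl on a core differing elsewhere, gives 55 nM, which suggests an alkylsulfonyl can retain measurable inhibition. A moderate loss from compound 2 is expected, a 2.9-fold higher number from compound 2 to compound 4 (0.47 log units; beyond the scatter). Compound 4 is estimated at 12 nM in this assay, within 3.5 nM to 45 nM.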

Compound 4, inhibition constant: 8.6 nM
The estimate for compound 4 lay 1.4-fold (0.14 log units) above the measured number; low and high end bracket the measured number.
By their numbers in this assay, from the lowest: compound 2; then compound 4; then compound 3; then compound 1.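

On the sulfonyl sulfur of this core, ethyl in place of (2-methoxyethyl)(methyl)amino gives a 2.1-fold higher number from compound 2 to compound 4 (0.32 log units; beyond the scatter) in this assay, a modest step that is nonetheless beyond the scatter. The whole (2-methoxyethyl)(methyl)amino group is therefore not needed for low-nanomolar inhibition at this position, as the much smaller ethyl leaves compound 4 at 8.6 nM. No supporting data bear on why the number shifts by this amount.

The step replaces the sulfamoyl nitrogen and the methoxyethyl chain together, so their separate contributions remain unresolved; a dimethylamino or a 2-methoxyethyl group on the same sulfur would separate them. From the compounds shown here alone, how far this position tolerates other groups also remains open, for example a cyclopropyl or a morpholine on the sulfonyl sulfur.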